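The source may hold more compounds than are shown below. What is called first, only, known or untested is meant among the compounds shown, and "the series" means these compounds.

Three compounds with a shared core, shown by compound 1 `CCN(CC)CCCNC(=O)c1ccc(C(CC)(CC)c2ccc(OCC(O)C(C)(C)C)c(C)c2)n1CC`, have been measured in an assay on HL-60 cells for agonist activity at vitamin D3 receptor (Homo sapiens), read by microscopy, with a stated time of 96 h; on this read-out higher numbers stand for an effect only at larger amounts of compound and lower numbers for an effect already at smaller amounts. Compound 1 gives 66 nM. Compound 2 `CCn1c(C(=O)NCC(OC)OC)ccc1C(CC)(CC)c1ccc(OCC(O)C(C)(C)C)c(C)c1` gives 150 nM in this assay, and compound 3 `CCn1c(C(=O)N(C)CCC#N)ccc1C(CC)(CC)c1ccc(OCC(O)C(C)(C)C)c(C)c1` gives 1960 nM, the highest of the three numbers, with compound 2 as its nearest neighbour and compound 1 as its furthest.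

Compound 4 `C=CCN(C)C(=O)c1ccc(C(CC)(CC)c2ccc(OCC(O)C(C)(C)C)c(C)c2)n1CC` has not yet been measured. It differs from compound 3 by vinyl in place of cyanomethyl on a saturated chain carbon bound to an amide-type nitrogen. Of the measured steps, a 2.3-fold higher number from compound 1 to compound 2 (0.36 log units; beyond the scatter) is the one that also sits on a saturated chain carbon bound to an amide-type nitrogen, and it was modest. The two larger steps, a 30-fold higher number from compound 1 to compound 3 (1.47 log units; beyond the scatter) and a 13-fold higher number from compound 2 to compound 3 (1.12 log units; beyond the scatter), changed the group on the carbonyl carbon itself and both raised the number in this assay. For the measured compounds named here, no measured pair shows what the loss of a nitrile alone does. The step from compound 3 to compound 4 is therefore expected to be of modest size, a 2.0-fold lower number from compound 3 to compound 4 (0.29 log units; within the scatter), more likely towards a lower number, though a result within the scatter would not surprise. The estimate for compound 4 in this assay is 1000 nM, expected to fall between 300 nM and 4000 nM.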

Compound 4, half-maximal effective concentration: 3950 nM
Compound 4: the middle estimate sits 4.0-fold (0.60 log units) below what was measured, and the stated range covers the measured number.
By their numbers in this assay, from the lowest: compound 1; then compound 2; then compounds 3 and 4 (each within the scatter of the next).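

In this assay, vinyl in place of cyanomethyl on a saturated chain carbon bound to an amide-type nitrogen gives a 2.0-fold higher number from compound 3 to compound 4 (0.30 log units; within the scatter) and so stays within the scatter, which shows that at this place the nitrile can be exchanged for a carbon-only end without a change that can be read. Compound 4 therefore sits with compound 3 well apart from the other two compounds, with a 26-fold higher number from compound 2 to compound 4 (1.42 log units; beyond the scatter) and a 60-fold higher number from compound 1 to compound 4 (1.78 log units; beyond the scatter) as large steps on the carbonyl carbon, so the allyl(methyl)amino and (2-cyanoethyl)(methyl)amino groups both go with high numbers, while the (2,2-dimethoxyethyl)amino and (3-(diethylamino)propyl)amino groups go with lower numbers. Nothing available here accounts for these steps.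

The compounds shown leave open whether the low number of compound 1 follows from its diethylamino group or from the amide hydrogen that it shares with compound 2. They also leave open how a saturated propyl chain in place of allyl, or a carboxylic acid at the end of the chain, would read in this assay.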